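Furan for Pyrrole on the Amide Carbonyl: Cytotoxicity Outlook

A few compounds are considered here, and "the series" means these few. Any claim that something is new, unique, unknown or untested is made for them only; others in the source may bear on it.

Measured compounds:
- compound 1, `Cc1cc[nH]c1C(=O)N1CCCn2nc(C(=O)Nc3ccccc3)cc2C1`: "not determined" (no result reported)
- compound 2, `O=C(Nc1ccccc1)c1cc2n(n1)CCCN(C(=O)c1occc1Cl)C2`: 30000 nM
- compound 3, `Cc1c(C(=O)N2CCCn3nc(C(=O)Nc4ccccc4)cc3C2)oc2ccccc12`: "not determined" (no result reported)

In an ADME assay on BEAS-2B cells (Homo sapiens) for cytotoxicity, read by fluorescence, with a stated time of 48 h (a lower number here means that less compound is tolerated, a higher number that more compound is tolerated), compound 1 has no number, and compound 3 likewise has none. Only compound 2 carries a value: in this assay compound 2 gives 30000 nM, a half-maximal cytotoxic concentration at the high end of what such cells tolerate.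

The compound still to be tested is compound 4, `Cc1coc(C(=O)N2CCCn3nc(C(=O)Nc4ccccc4)cc3C2)c1C`. It differs from compound 1 by 3,4-dimethylfuran-2-yl in place of 3-methyl-1H-pyrrol-2-yl on a carbonyl carbon. For the measured compounds named here, compound 1 has no number of its own in this assay, so no step size can be anticipated for it; the only anchor is compound 2 at 30000 nM, and nothing among the measured compounds suggests compound 4 should deviate beyond the scatter from that level. Compound 4 is therefore expected to give about 30000 nM, within a range from 10000 nM to 100000 nM.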

Compound 4, half-maximal cytotoxic concentration: 30000 nM
Compound 4: the middle estimate sits on the measured number at the digits printed; the range from low to high includes it.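

In this assay, 3,4-dimethylfuran-2-yl in place of 3-chlorofuran-2-yl on a carbonyl carbon gives no change at the digits printed from compound 2 to compound 4 (within the scatter). For the compounds shown here, this is the first comparison that can be read at this position, and it shows that exchanging the chlorine for two methyl groups on the furan leaves the half-maximal cytotoxic concentration unchanged within the scatter. No supporting data offer an explanation for this result.

The steps involving compound 1 and compound 3 cannot be read, so the furan-for-pyrrole change remains unresolved. On these data alone, it also remains open whether a furan carrying an amine or a carboxylic acid would hold this level.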